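Removing the Ring Hydroxy from a Cyclobutane Antagonist

The source may report more compounds than this note shows. Statements on the series, on what has been measured and on what is new or still open speak of the compounds shown alone.

Of the compounds shown here, three sharing one core have been tested in an assay on HEK293 cells for antagonist activity at transient receptor potential cation channel subfamily V member 3 (Homo sapiens), read by FLIPR and calcium flux; a higher number here means a weaker inhibitor, a lower number a stronger inhibitor. Compound 2 `O[C@H](c1ccccn1)[C@]1(c2cccc(OC(F)(F)F)c2)C[C@H](O)C1` gives 40 nM, the lowest number of the three. Compound 1 `O[C@H](c1ccccn1)[C@]1(c2cccc(OC(F)(F)F)c2)C[C@@H](O)C1` gives 80 nM, and a 2.0-fold lower number from compound 1 to compound 2 (0.30 log units; within the scatter); these two are the same molecule drawn with the opposite configuration at the two ring stereocentres, and the fact that compounds 1 and 2 differ only in the configuration as drawn is the only thing that separates them. Compound 3 `O[C@H](c1ccccn1)[C@]1(c2cccc(C(F)(F)F)c2)C[C@H](O)C1` gives 90 nM, and a 2.3-fold higher number from compound 2 to compound 3 (0.35 log units; beyond the scatter); it carries trifluoromethyl instead of trifluoromethoxy on the aromatic ring.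

Compound 4 `O[C@H](c1ccccn1)C1(c2cccc(OC(F)(F)F)c2)CCC1` has not yet been measured. Compared with compound 2 the change is hydrogen in place of hydroxy on a saturated ring carbon, on a saturated ring carbon of the four-membered ring, two ring bonds away from the carbon bearing the hydroxy(pyridin-2-yl)methyl group. Going by the values given here, no measured step removes this hydroxy; the nearest evidence is the step from compound 1 to compound 2, where flipping the configuration of the same ring carbon stays within the scatter, while the step from compound 2 to compound 3 concerns a different part of the molecule. Removing a hydrogen-bond donor and acceptor is expected to cost some affinity, so compound 4 is expected to give 150 nM, between 50 nM and 500 nM. The expected change is a 3.8-fold higher number from compound 2 to compound 4 (0.57 log units; beyond the scatter).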

Compound 4, antagonist equilibrium constant: 80 nM
Beside the measured number, compound 4's estimate is 1.9-fold (0.27 log units) above it; measured number inside the range.
By their numbers in this assay, from the lowest: compounds 2, 1, 4 and 3 (each within the scatter of the next, the first and the last beyond it).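

In this assay, the ring hydroxy proves dispensable at the resolution of these numbers: hydrogen in its place gives a 2.0-fold higher number from compound 2 to compound 4 (0.30 log units; within the scatter), and no change at the digits printed from compound 1 to compound 4 (within the scatter). Neither step leaves the scatter, so at this position, on a saturated ring carbon two ring bonds from the ring atom that bears a hydroxy(pyridin-2-yl)methyl group, the loss of one hydrogen-bond donor and one acceptor shows no effect that this assay can separate from repeat-to-repeat variation, whichever way the hydroxy is drawn. Compound 4 has thus been compared with both drawn forms of the hydroxy compound, so the same change is tested twice, and the two comparisons agree: the fact that compounds 1 and 2 differ only in the configuration as drawn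

The compounds shown leave open whether other groups on this ring carbon, such as an amine, a methoxy group or a carboxylic acid, would keep the number in the same range as hydroxy and hydrogen. Also open, from the compounds shown here alone, is whether hydrogen in place of hydroxy reads the same way on compound 3, which carries trifluoromethyl instead of trifluoromethoxy on the aromatic ring.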